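Swapping the Amine on a Lipid-Like Carbamate Scaffold

This account rests on a few compounds, and the source may have more. Where it says the series, first, only, none or still open, it means among the compounds named here.

Compound 1 `CCCCCCCCCCCCCC[C@H](OCOC)[C@H](CN(C(C)C)C(C)C)NC(=O)OC(C)(C)C` and compound 2 `CCCCCCCCCCCCCC[C@H](OCOC)[C@H](CN(CCCC)CCCC)NC(=O)OC(C)(C)C` share one core, while compound 3 `CCCCCCCCCCCCCC[C@H](O)[C@H](CN(C(C)C)C(C)C)NC(=O)OC(C)(C)C` and compound 4 `CCCCCCCCCCCCCC[C@H](O)[C@H](CN(CCCC)CCCC)NC(=O)OC(C)(C)C` share another. The two cores differ by hydrogen in place of methoxymethyl on an oxygen on a saturated carbon. In a functional assay on A549 cells (Homo sapiens) for antiproliferative activity, read by sulforhodamine B assay, with a stated time of 48 h, tested at 10 uM (on this read-out higher numbers stand for more inhibition at the one concentration tested (going by the name of the read-out) and lower numbers for less inhibition), compound 1 gives 22.6% and compound 3 gives 22.9%, a step of a number 0.3 percentage points higher from compound 1 to compound 3 (within the scatter). Within the first core, the change dibutylamino in place of diisopropylamino on a saturated chain carbon, two bonds along the chain from an amide-type nitrogen gives compound 2 a reading of 42.2% in this assay, a step of a number 19.6 percentage points higher from compound 1 to compound 2 (beyond the scatter). Compound 4 carries the same change, (dibutylamino in place of diisopropylamino on a saturated chain carbon, two bonds along the chain from an amide-type nitrogen), at the same place. Because the core step a number 0.3 percentage points higher from compound 1 to compound 3 (within the scatter) is within the scatter of the measurement, the amine swap is expected to behave alike, and compound 4 is expected to show a step of a number 19.1 percentage points higher from compound 3 to compound 4 (beyond the scatter) in this assay. Compound 4 is therefore estimated at 42%, with a plausible range from 28% to 56%, a single measured pair being a thin basis.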

Compound 4, a percentage reported as inhibition, at one concentration (the size of the read-out at that concentration, not a potency): 30%
Estimate against measurement, compound 4: 12 percentage points above; the measured number falls inside the stated range.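

The swap to dibutylamino gives a number 7.1 percentage points higher from compound 3 to compound 4 (within the scatter) in this assay, and this step cannot be told apart from the one on the core of compound 1: the same change on two cores in this assay, a number 19.6 percentage points higher (beyond the scatter) from compound 1 to compound 2 and a number 7.1 percentage points higher (within the scatter) from compound 3 to compound 4, 12.5 percentage points apart, within the scatter of two such steps. Removing the methoxymethyl group gives a number 12.2 percentage points lower from compound 2 to compound 4 (beyond the scatter), and this step likewise cannot be told apart from the same change made with diisopropylamino: the same change on two cores in this assay, a number 0.3 percentage points higher (within the scatter) from compound 1 to compound 3 and a number 12.2 percentage points lower (beyond the scatter) from compound 2 to compound 4, 12.5 percentage points apart, within the scatter of two such steps. So these four compounds show no clear difference in how the amine swap behaves on the two cores, but with one pair per core they do not prove that it carries over unchanged.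

The compounds shown leave open how other amines, such as dihexylamino or piperidine, would read. Also open, as far as these compounds go, is what a free primary amine in place of the carbamate would do.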